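A few compounds are considered here, and "the series" means these few. Any claim that something is new, unique, unknown or untested is made for them only; others in the source may bear on it.

Compound 2 `COc1ccc(-c2cc(C(=O)Nc3ccc(Oc4ccnc5cc(OCCCN6CCCCC6)c(OC)cc45)c(F)c3)c3ccccc3n2)cc1` stands at the lower of the two numbers in hand, though the two lie within the scatter of each other: in a functional assay on SMMC-7721 cells (Homo sapiens) for cytotoxicity, read by MTT assay, with a stated time of 72 h (on this read-out lower numbers stand for stronger inhibition and higher numbers for weaker inhibition), compound 2 gives 210 nM, and compound 1 `COc1cc2c(Oc3ccc(NC(=O)c4cc(-c5ccccc5)nc5ccccc45)cc3F)ccnc2cc1OCCCN1CCCCC1` gives 290 nM. The step of a 1.4-fold lower number from compound 1 to compound 2 (0.14 log units; within the scatter) therefore says little about which is the stronger inhibitor. Compound 3 `COc1cc2c(Oc3ccc(NC(=O)c4cc(-c5ccc(F)cc5)nc5ccccc45)cc3F)ccnc2cc1OCCCN1CCCCC1` differs from compound 2 by fluoro in place of methoxy on an aromatic carbon. Within the data shown here, the only measured step that bears on this carbon is a 1.4-fold lower number from compound 1 to compound 2 (0.14 log units; within the scatter), where methoxy replaced hydrogen; that step stayed within the scatter. Among the measured compounds shown here, since the one change seen at this place did not move the number beyond the scatter, the expected step in this assay is a 1.2-fold higher number from compound 2 to compound 3 (0.09 log units; within the scatter), that is, none beyond the scatter. Compound 3 is accordingly estimated at 260 nM, with a range from 120 nM to 550 nM.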

Compound 3, half-maximal inhibitory concentration: 74 nM
Beside the measured number, compound 3's estimate is 3.5-fold (0.55 log units) above it; measured number below the stated range.
By their numbers in this assay, from the lowest: compound 3; then compounds 2 and 1 (each within the scatter of the next).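

In this assay this carbon, para to a large group, no longer looks indifferent: the change from 4-methoxyphenyl to 4-fluorophenyl brings a 2.8-fold lower number from compound 2 to compound 3 (0.45 log units; beyond the scatter) and fluoro in place of hydrogen brings a 3.9-fold lower number from compound 1 to compound 3 (0.59 log units; beyond the scatter) at the same carbon. Both steps lie beyond the scatter, unlike the earlier one from hydrogen to methoxy, so the group placed here can change the number, and compound 3 now stands clear of both other compounds as the strongest inhibitor of the three. Nothing available explains why fluoro differs from methoxy and hydrogen here.

On these data alone, whether this result is particular to fluoro remains open, since chloro, a nitrile or an amine on this carbon would show how other groups compare. Also open, as far as these compounds go, is whether fluoro keeps a step of this size when the piperidine-bearing side chain is replaced by a shorter chain or a carboxylic acid.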